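Methylation of the anilino nitrogen in the shared core

The compounds below may be only part of what the source reports. "The series", "measured", "known", "first", "only" and "open" are said of these compounds alone.

For the measured compounds named here, compound 3 `c1ccc(Nc2nccc(-c3ccncc3)n2)cc1` sits at the lower end of the two numbers so far: in a functional assay for inhibition, with Homo sapiens as the target (a higher number here means a weaker inhibitor, a lower number a stronger inhibitor), compound 3 gives 900 nM. Going by the values given here, compound 1 `CCOC(=O)C(=O)N(c1ccccc1)c1nccc(-c2ccncc2)n1` gives 2200 nM in this assay, and the step of a 2.4-fold lower number from compound 1 to compound 3 (0.39 log units; beyond the scatter) is the only measured change on that nitrogen. Compound 2 `COc1ccc(N(C)c2nccc(-c3ccncc3)n2)cc1` reaches only a limit of the assay, > 24000 nM; this is the limit of > 24000 nM in this assay, at which 1 of the 3 values shown sits, so it yields no number.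

Compound 4 `CN(c1ccccc1)c1nccc(-c2ccncc2)n1` differs from compound 3 by methyl in place of hydrogen on a nitrogen on an aromatic ring. Among the compounds with values here, the single step that bears on this position, a 2.4-fold lower number from compound 1 to compound 3 (0.39 log units; beyond the scatter), shows that occupying the nitrogen with a larger group costs a modest amount; removing it recovers it. Compound 2 also carries a methyl on that nitrogen, though it differs elsewhere as well, and its value is a limit rather than a number. Both observations point the same way, a weakening, with the size uncertain.

Compound 4 is therefore expected to give a higher number than compound 3, an estimated step of a 6.7-fold higher number from compound 3 to compound 4 (0.82 log units; beyond the scatter) in this assay. The estimate for compound 4 is 6000 nM, with a range from 1800 nM to 24000 nM, and a real chance that only a limit is reported.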

Compound 4, half-maximal inhibitory concentration: > 24000 nM
Compound 4 gave a limit, no number; the forecaster's own chance of this, stated with the estimate: 25%; at least 4.0-fold (0.60 log units) between middle value and limit.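

In this assay, methyl in place of hydrogen on the nitrogen on an aromatic ring proves a large change, with an at least 26-fold higher number from compound 3 to compound 4 (1.42 log units; beyond the scatter). The cost at this nitrogen does not follow the size of the group, since the single carbon of methyl gives a far higher number than the larger (ethoxycarbonyl)carbonyl, with an at least 10-fold higher number from compound 1 to compound 4 (1.03 log units; beyond the scatter); compound 1 therefore goes against any simple order by size. The step from compound 2 to compound 4 joins two limits and cannot be read, so the methoxy on an aromatic carbon cannot be judged with the methyl in place.

Going by these compounds, the value of compound 4 is a limit and not a number, so the full size of the loss stays open: the limit of > 24000 nM in this assay, at which 2 of the 4 values shown sit. Also open is how an acetyl group or an ethyl group on this nitrogen would compare with the hydrogen of compound 3 and with the (ethoxycarbonyl)carbonyl of compound 1.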